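The source may hold more compounds than are shown below. What is called first, only, known or untested is meant among the compounds shown, and "the series" means these compounds.

Of the compounds shown here, three sharing one core have so far been measured in an ADME assay on microsomes from liver (Homo sapiens) for metabolic stability; on this read-out higher numbers stand for fast clearance and lower numbers for slow clearance. Compound 1 `O=C(N[C@H]1CCC[C@H](CO)C1)C1CCN(c2nc3cc(Cl)c(Cl)cc3o2)CC1` gives 27.1 mL/min/kg, and compound 3 `O=C(N[C@H]1CCC[C@H](CO)C1)C1CCN(c2nc3cc(Br)ccc3o2)CC1` gives 25.6 mL/min/kg. Compound 2 `O=C(N[C@H]1CCC[C@H](CO)C1)C1CCN(c2nc3cc(Cl)c(-c4cccc(Cl)c4)cc3o2)CC1` gives 55.8 mL/min/kg, the highest of the three numbers: the step of a 2.1-fold higher number from compound 1 to compound 2 (0.31 log units; beyond the scatter) lies between it and its nearest neighbour, and its gap to compound 3 is of about the same size and likewise beyond the scatter.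

Compound 4 `CC(C)c1cc2oc(N3CCC(C(=O)N[C@H]4CCC[C@H](CO)C4)CC3)nc2cc1Cl` has not yet been measured. It differs from compound 2 in a single place: isopropyl in place of 3-chlorophenyl on an aromatic carbon. Among the compounds with values here, the one measured step that bears on this change is a 2.1-fold higher number from compound 1 to compound 2 (0.31 log units; beyond the scatter), in which a 3-chlorophenyl group entered at this very position and the number rose. Compound 4 takes that group away again, but puts isopropyl in its place rather than chloro, so the change is not a plain reversal of that step. A lower number is therefore expected, though probably not all the way back to where compound 1 stands. The step expected in this assay is a 1.6-fold lower number from compound 2 to compound 4 (0.20 log units; within the scatter). Compound 4 is estimated at 35 mL/min/kg, with a likely range from 20 mL/min/kg to 60 mL/min/kg.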

Compound 4, clearance: 46.4 mL/min/kg
Estimate against measurement, compound 4: 1.3-fold (0.12 log units) below; the measured number falls inside the stated range.
By their numbers in this assay, from the lowest: compounds 3, 1, 4 and 2 (each within the scatter of the next, the first and the last beyond it).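

In this assay the swap of 3-chlorophenyl for isopropyl gives a 1.2-fold lower number from compound 2 to compound 4 (0.08 log units; within the scatter) and the swap of chloro for isopropyl on the same aromatic carbon gives a 1.7-fold higher number from compound 1 to compound 4 (0.23 log units; within the scatter), so neither change can be told apart from repeat-measurement noise. The chloro and 3-chlorophenyl groups are separated by a 2.1-fold higher number from compound 1 to compound 2 (0.31 log units; beyond the scatter), yet isopropyl, which has no ring, cannot be placed with either of them, and the clear step seen earlier now has a middle point that belongs to neither side. Nothing shown gives a measured reason for these numbers.

From the compounds shown here alone, what remains open is whether the ring of 3-chlorophenyl, its chlorine or simply the number of atoms at this carbon matters for clearance, which a plain phenyl or a methyl group could help to separate. Going by these compounds, it is also open how this position would respond to a group of a different kind, such as an amine or a carboxylic acid, since the three groups compared here all have no hydrogen-bond donors, no hydrogen-bond acceptors and no net charge.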